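A few compounds are considered here, and "the series" means these few. Any claim that something is new, unique, unknown or untested is made for them only; others in the source may bear on it.

Values in a functional assay on CCRF-CEM cells (Homo sapiens) for cytotoxicity, in the absence of a further agent; a lower number here means a stronger inhibitor, a higher number a weaker inhibitor:
- Compound 1 `Nc1nc(N)c(CCCN(Cc2ccc(NC(CCC(=O)O)C(=O)O)cc2)c2cc(F)c(F)cc2[N+](=O)[O-])c(O)n1`: > 100000 nM
- Compound 2 `CC(C)(C)OC(=O)CCC(Nc1ccc(CN(CCCc2c(N)nc(N)nc2O)c2cc(F)cc(F)c2[N+](=O)[O-])cc1)C(=O)OC(C)(C)C`: 13000 nM
- Compound 3 `Nc1nc(N)c(CCCN(Cc2ccc(NC(CCC(=O)O)C(=O)O)cc2)c2ccc([N+](=O)[O-])c(F)c2F)c(O)n1`: > 100000 nM

Compound 1 shows > 100000 nM, which is a limit of the assay and not a number. Compound 3 shows > 100000 nM, which is also a limit. Among the compounds with values here, compound 2, at 13000 nM, therefore holds the only true number in this assay.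

Compound 4 `CC(C)(C)OC(=O)CCC(Nc1ccc(CN(CCCc2c(N)nc(N)nc2O)c2ccc([N+](=O)[O-])c(F)c2F)cc1)C(=O)OC(C)(C)C` has not yet been measured. It is built from the same atoms as compound 2, joined differently: 2,3-difluoro-4-nitrophenyl in place of 3,5-difluoro-2-nitrophenyl on an amine nitrogen. In words, 2,3-difluoro-4-nitrophenyl stands in place of 3,5-difluoro-2-nitrophenyl on an amine nitrogen.

Within the data shown here, the only measured step that brings in the same new group is a step that the two limits leave unreadable from compound 1 to compound 3. Both of its ends sit at the limit of > 100000 nM in this assay, at which 2 of the 3 values shown sit, so it gives no size to carry over. The expectation therefore rests on compound 2 at 13000 nM, and no shift beyond the usual scatter is assumed. The expected change is a 1.1-fold higher number from compound 2 to compound 4 (0.03 log units; within the scatter). Compound 4 is estimated at 14000 nM, with an expected range of 4000 nM to 50000 nM.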

Compound 4, half-maximal inhibitory concentration: 24000 nM
Estimate against measurement, compound 4: 1.7-fold (0.23 log units) below, within the range that was stated.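

In this assay, the 2,3-difluoro-4-nitrophenyl group in place of the 3,5-difluoro-2-nitrophenyl group on the amine nitrogen gives a 1.8-fold higher number from compound 2 to compound 4 (0.27 log units; within the scatter). Within the data shown here, this is the first readable size for a change of this group: the two compounds hold the same atoms, joined differently, and moving the ring's substituents leaves them within the scatter of each other. The step from compound 1 to compound 3, which brings in the same group, cannot be read, since both of its ends are limits: the limit of > 100000 nM in this assay, at which 2 of the 4 values shown sit.

Going by these compounds, what stays open is how far this ring can change, for example with a nitrile in place of the nitro group or with a single fluorine. Also open, on these data alone, is whether an amide in place of each tert-butyl ester would give a readable number in this assay.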